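Swapping the Benzyl Ester Arm for an Amino Chain

The source may hold more compounds than are shown below. What is called first, only, known or untested is meant among the compounds shown, and "the series" means these compounds.

Compound 3 `O=C(CN(c1nc(Cl)nc2[nH]cnc12)C1CC1)N[C@@H](CC(=O)OCc1ccccc1)C(=O)OCc1ccccc1` gives 22.4% in a functional assay on the whole organism (Tail, strain ICR) with Mus musculus as the target, in the tail flick test, with a stated time of 60 min, at a dose of 25 umol/kg by the oral route (a lower number here means a weaker effect, a higher number a stronger effect of the compound at the dose given), the lowest of the three measured numbers. Compound 1 `O=C(CN(c1nc(Cl)nc2[nH]cnc12)C1CC1)NCC(=O)OCc1ccccc1` gives 41.9% and compound 2 `CC(C)[C@H](NC(=O)CN(c1nc(Cl)nc2[nH]cnc12)C1CC1)C(=O)OCc1ccccc1` gives 55.5%. The step of a number 19.5 percentage points lower from compound 1 to compound 3 (beyond the scatter) and the step of a number 33.1 percentage points lower from compound 2 to compound 3 (beyond the scatter) both show that (benzyloxycarbonyl)methyl at that chain carbon goes with a weaker effect than hydrogen or isopropyl. Compound 4 `NCCCC[C@H](NC(=O)CN(c1nc(Cl)nc2[nH]cnc12)C1CC1)C(=O)OCc1ccccc1` differs from compound 3 in one place: 3-aminopropyl in place of benzyloxycarbonyl on a saturated chain carbon, two bonds along the chain from an amide-type nitrogen and a carbonyl carbon. For the measured compounds named here, no measured step contains an amine, so the size is uncertain, but a rise is expected because a number 19.5 percentage points lower from compound 1 to compound 3 (beyond the scatter) ran the other way when the benzyloxycarbonyl arm was present. The expected step is a number 17.6 percentage points higher from compound 3 to compound 4 (beyond the scatter). For compound 4 the estimated activity is 40%, within a range from 20% to 62%.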

Compound 4, a percentage reported as activity, at one dose (the size of the read-out at that dose, not a potency): 41.2%
Estimate against measurement, compound 4: 1.2 percentage points below, and the stated range covers the measured number.
By their numbers in this assay, from the lowest: compound 3; then compounds 4 and 1 (each within the scatter of the next); then compound 2.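

The first amine at this chain carbon shows that a charge-free count of size alone does not set the read-out: in this assay, 4-aminobutyl and plain hydrogen cannot be told apart, with a number 0.7 percentage points lower from compound 1 to compound 4 (within the scatter). The amine chain still gives a weaker effect than isopropyl, with a number 14.3 percentage points lower from compound 2 to compound 4 (beyond the scatter), and a stronger effect than the benzyl ester arm, with a number 18.8 percentage points higher from compound 3 to compound 4 (beyond the scatter). Nothing here explains these differences.

From the compounds shown here alone, what a carboxylic acid or a shorter 2-aminoethyl chain would give on this same chain carbon remains open.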